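Adding a Second Hydroxy to a Thiazole-Hydrazone Cytotoxin

The source may report more compounds than this note shows. Statements on the series, on what has been measured and on what is new or still open speak of the compounds shown alone.

Measured so far:
compound 1 `Oc1ccc(/C=N/Nc2nc3ccccc3s2)cc1O` gives 33%
compound 2 `COc1cc(/C=N/Nc2nc3ccccc3s2)ccc1O` gives 44%

In a functional assay on cells (Mus musculus) for cytotoxicity, read by MTT assay, with a stated time of 24 h, tested at 1 uM (a lower number here means a weaker effect, a higher number a stronger effect of the compound at the concentration tested), compound 2 stands highest of the two numbers; the step of a number 11 percentage points higher from compound 1 to compound 2 (beyond the scatter) is modest. Compound 3 `COc1cc(/C=N/Nc2nc3ccccc3s2)cc(O)c1O` differs from compound 2 by hydroxy in place of hydrogen on an aromatic carbon, the new group ortho to a hydroxy group and meta to a methoxy group. Among the measured compounds shown here, no measured step involves a hydroxy entering, so only the single methyl-for-hydrogen step offers any guide, and it does not transfer. The expected change a number 4 percentage points lower from compound 2 to compound 3 (within the scatter) is therefore small, within scatter. Compound 3 is estimated at 40%, in the range 25% to 55%.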

Compound 3, a percentage reported as activity, at one concentration (the size of the read-out at that concentration, not a potency): 38%
The estimate for compound 3 lay 2 percentage points above the measured number, within the range that was stated.
By their numbers in this assay, from the lowest: compounds 1, 3 and 2 (each within the scatter of the next, the first and the last beyond it).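

In this assay, hydroxy in place of hydrogen on this aromatic carbon, ortho to a hydroxy group and meta to a methoxy group, gives a number 6 percentage points lower from compound 2 to compound 3 (within the scatter) and so produces no measurable change at this position. A second comparison gives a number 5 percentage points higher from compound 1 to compound 3 (within the scatter) and so places compound 3 within reach of compound 1 as well, although compound 1 and compound 2 stand apart. No measurement here explains these results.

As far as these compounds go, how an amine or a carboxylic acid on this carbon would read remains open. So does whether a hydroxy here would matter at other concentrations.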